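The source may hold more compounds than are shown below. What is called first, only, known or untested is meant among the compounds shown, and "the series" means these compounds.

Compound 1 `Cc1c(-c2ccc(-c3ccccc3F)cc2)nc2ccc(F)cc2c1C(O)C(F)(F)F`: 640 nM
Compound 2 `Cc1c(-c2ccc(-c3ccccc3F)cc2)nc2ccc(F)cc2c1C(N)=O`: 128 nM

In a functional assay on MOLM-13 cells (Homo sapiens) for antiproliferative activity (a higher number here means a weaker inhibitor, a lower number a stronger inhibitor), compound 1, at 640 nM, has the higher of the two numbers. Compound 3 `Cc1c(-c2ccc(-c3ccccc3F)cc2)nc2ccc(F)cc2c1C(=O)NO` has not yet been measured. It departs from compound 1 by hydroxycarbamoyl in place of 2,2,2-trifluoro-1-hydroxyethyl on an aromatic carbon, with hydroxycarbamoyl in place of 2,2,2-trifluoro-1-hydroxyethyl on an aromatic carbon. Within the data shown here, one measured step bears on this change: a 5.0-fold lower number from compound 1 to compound 2 (0.70 log units; beyond the scatter), modest but beyond the scatter, where carbamoyl enters at that same carbon. On these data alone, a step of similar size towards a lower number is therefore expected in this assay, though hydroxycarbamoyl itself is untested. The expected step is a 4.3-fold lower number from compound 1 to compound 3 (0.63 log units; beyond the scatter). The estimate for compound 3 is 150 nM, with an expected range of 35 nM to 640 nM.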

Compound 3, half-maximal inhibitory concentration: 23 nM
For compound 3 the middle estimate is 6.5-fold (0.81 log units) above the measured one; measured number below the stated range.
By their numbers in this assay, from the lowest: compound 3; then compound 2; then compound 1.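

In this assay, the aromatic carbon opposite the ring nitrogen proves far more responsive than the carbamoyl step alone suggested, with hydroxycarbamoyl in place of 2,2,2-trifluoro-1-hydroxyethyl giving a 28-fold lower number from compound 1 to compound 3 (1.44 log units; beyond the scatter) in a single change. Hydroxy in place of hydrogen on the amide-type nitrogen then adds a distinct gain, a 5.6-fold lower number from compound 2 to compound 3 (0.75 log units; beyond the scatter), so carbamoyl does not mark the limit at this carbon. No evidence is available on what lies behind this gain. Still open, on these data alone, is whether a carboxylic acid at this carbon, or a methoxy on the amide-type nitrogen, would match hydroxycarbamoyl.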